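Adding Methoxy to Nitro Compound 3

The compounds below may be only part of what the source reports. "The series", "measured", "known", "first", "only" and "open" are said of these compounds alone.

In a functional assay on B16 cells (Mus musculus) for antiproliferative activity, read by MTT assay, with a stated time of 72 h (a higher number here means a weaker inhibitor, a lower number a stronger inhibitor), compound 1 (`COc1cc(/C(=C/c2ccccc2)C(C)O)cc(OC)c1OC`) gives > 100000 nM as a limit of the assay, not a number. Compound 2 (`COc1cc(/C(=C/c2ccc(Br)cc2)C(C)O)cc(OC)c1OC`) gives > 100000 nM as a limit too. Compound 3 (`COc1cc(/C(=C/c2cccc([N+](=O)[O-])c2)C(C)O)cc(OC)c1OC`) stands at > 100000 nM as a limit as well. Across these compounds, the limit of > 100000 nM in this assay, at which 3 of the 3 values shown sit, is all that can be read. The change to compound 4 (`COc1ccc(/C=C(/c2cc(OC)c(OC)c(OC)c2)C(C)O)cc1[N+](=O)[O-]`) is methoxy in place of hydrogen on an aromatic carbon and it puts methoxy in place of hydrogen on an aromatic carbon. Within the data shown here, two measured steps bear on it, a step that the two limits leave unreadable from compound 1 to compound 2 and a step that the two limits leave unreadable from compound 1 to compound 3 and neither gives a size to carry over. Any step expected in this assay is therefore uncertain, with a modest move towards stronger inhibition at most. The expected result is an at least 2.0-fold lower number from compound 3 to compound 4 (0.30 log units; that floor lies within the scatter) as a rough guess. Compound 4 is estimated at 50000 nM with an expected range from 3000 nM to 150000 nM in this measurement.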

Compound 4, half-maximal inhibitory concentration: > 100000 nM
Compound 4: only a limit was reported; the forecaster's own chance of this, stated with the estimate: 55%; middle value at least 2.0-fold (0.30 log units) from the limit.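

Compound 3 and compound 4 both sit at a limit, so no step between them can be read: the limit of > 100000 nM in this assay, at which 4 of the 4 values shown sit.

The compounds shown leave open what size, if any, the methoxy change has, and which change to the shared core would give a readable number.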